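Chloro for Methoxy, Repeated on a Second Core

The source may hold more compounds than are shown below. What is called first, only, known or untested is meant among the compounds shown, and "the series" means these compounds.

Compound 1 `COc1ccc(C(=O)CSc2nc3c([nH]2)c(=O)n(C)c(=O)n3C)cc1` and compound 2 `Cn1c(=O)c2[nH]c(SCC(=O)c3ccc(Cl)cc3)nc2n(C)c1=O` share one core and differ in a single place: chloro in place of methoxy on an aromatic carbon. In a functional assay on A549 cells (Homo sapiens) for inhibition, read by MTT assay, with a stated time of 48 h (on this read-out lower numbers stand for stronger inhibition and higher numbers for weaker inhibition), compound 1 gives 7900 nM, and compound 2 gives 8400 nM; the step is a 1.1-fold higher number from compound 1 to compound 2 (0.03 log units; within the scatter). Compound 3 `COc1ccc(/C(CSc2nc3c([nH]2)c(=O)n(C)c(=O)n3C)=N\O)cc1` carries a different core, and the difference between the core of compound 1 and the core of compound 3 is not broken down here. In this assay compound 3 gives 1500 nM, the lowest of the three numbers, with its steps to compound 1 and to compound 2 both lying beyond the scatter. Compound 4 `Cn1c(=O)c2[nH]c(SC/C(=N/O)c3ccc(Cl)cc3)nc2n(C)c1=O` stands to compound 3 exactly as compound 2 stands to compound 1: chloro in place of methoxy on an aromatic carbon, the same change, made twice among these compounds. Because the earlier step of a 1.1-fold higher number from compound 1 to compound 2 (0.03 log units; within the scatter) stayed within the scatter, the new one is expected to do the same. Compound 4 is thus expected to move only slightly from its parent, as a 1.1-fold higher number from compound 3 to compound 4 (0.05 log units; within the scatter). The estimate for compound 4 in this assay is 1700 nM, between 800 nM and 3800 nM.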

Compound 4, half-maximal inhibitory concentration: 1500 nM
Estimate against measurement, compound 4: 1.1-fold (0.05 log units) above; measured number inside the range.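

In this assay, the change from 4-methoxyphenyl to 4-chlorophenyl on the second core gives no change at the digits printed from compound 3 to compound 4 (within the scatter), which matches what the same change did on the first core. Set side by side, the two steps do not differ: the same change on two cores in this assay, a 1.1-fold higher number (0.03 log units; within the scatter) from compound 1 to compound 2 and no change at the digits printed (within the scatter) from compound 3 to compound 4, 1.1-fold (0.03 log units) apart, within the scatter of two such steps

This shows that, for these two pairs, the change carried from one core to the other without altering the read-out beyond the scatter. It does not show that the same would hold on any further core, and since neither step moved the number beyond the scatter, it cannot tell whether the two cores would respond alike to a change that does.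

The compounds shown leave open whether an amine or a carboxylic acid on that same aromatic carbon would behave the same way on both cores. Also open, from the compounds shown here alone, is what would happen if a longer chain stood in place of the methyl groups on the cores.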